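The source may hold more compounds than are shown below. What is called first, only, known or untested is meant among the compounds shown, and "the series" means these compounds.

In a functional assay on A549/CDDP cells (Homo sapiens) for antiproliferative activity, read by MTT assay, with a stated time of 72 h (a lower number here means a stronger inhibitor, a higher number a weaker inhibitor), compound 1 (`Cc1nc(C)c(/C=C/C(=O)/C=C/c2ccc(O)cc2)nc1C`) gives 4790 nM, and compound 3 (`COc1cccc(/C=C/C(=O)/C=C/c2nc(C)c(C)nc2C)c1`) lies within the scatter of it at 3440 nM. Compound 2 (`COc1cc(/C=C/C(=O)/C=C/c2nc(C)c(C)nc2C)ccc1O`) stands clearly apart at 600 nM. The next compound, compound 4 (`Cc1nc(C)c(/C=C/C(=O)/C=C/c2ccc(Cl)cc2)nc1C`), has chloro in place of hydroxy on an aromatic carbon, para to a large group: chloro in place of hydroxy on an aromatic carbon.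

Among the compounds with values here, no measured step makes this exchange. The closest is hydrogen in place of hydroxy on an aromatic carbon, which gave a 5.7-fold higher number from compound 2 to compound 3 (0.76 log units; beyond the scatter), although that step was measured on a methoxy-bearing compound, and compound 4 carries no methoxy. Methoxy in place of hydrogen gave an 8.0-fold lower number from compound 1 to compound 2 (0.90 log units; beyond the scatter), a change that compound 4 does not share, so it bears only indirectly. From the compounds shown here alone, with so little direct evidence, no clear shift is expected, and the direction remains open. The estimated change is a 1.2-fold lower number from compound 1 to compound 4 (0.08 log units; within the scatter), which is expected to stay within the scatter. For compound 4 the estimated value is 4000 nM, with an expected range from 1300 nM to 12000 nM.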

Compound 4, half-maximal inhibitory concentration: 7490 nM
Beside the measured number, compound 4's estimate is 1.9-fold (0.27 log units) below it; the measured number falls inside the stated range.
By their numbers in this assay, from the lowest: compound 2; then compounds 3, 1 and 4 (each within the scatter of the next, the first and the last beyond it).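

In this assay, chloro in place of hydroxy, which turns the 4-hydroxyphenyl into a 4-chlorophenyl, gives a 1.6-fold higher number from compound 1 to compound 4 (0.19 log units; within the scatter). This is the first exchange shown at this position on a compound without methoxy, since the earlier step that removed hydroxy was read on a methoxy-bearing compound; here, the loss of the hydroxy with its hydrogen-bond donor and acceptor, and the entry of chloro, leave the number within the scatter. Nothing given here explains this result.

The compounds shown leave open whether chloro would also leave the number within the scatter on a methoxy-bearing compound such as compound 2. They also leave open how an amine or a carboxylic acid would read on this aromatic carbon, para to a large group.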